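Estimating a Hydroxybenzamide Analogue in Paw Edema Inhibition

The source may hold more compounds than are shown below. What is called first, only, known or untested is meant among the compounds shown, and "the series" means these compounds.

Compound 1 `N#CC1=C(NCC(=O)O)N(c2ccccc2)C(=O)N2CCCCC(N3CCCC3)C12`, compound 2 `N#CC1=C(/N=C/Nc2ccc([N+](=O)[O-])cc2)N(c2ccccc2)C(=O)N2CCCCC(N3CCCC3)C12` and compound 3 `COc1ccc(/C=N/C2=C(C#N)C3C(N4CCCC4)CCCCN3C(=O)N2c2ccccc2)cc1` share one core and differ only in the group carried on a double-bonded ring carbon. In a functional assay on the whole organism (strain albino) for inhibition, with Rattus norvegicus as the target, read by paw edema, with stated times of 1 h and 3 h, at a dose of 20 mmol/kg by the intraperitoneal route (a lower number here means a weaker effect, a higher number a stronger effect of the compound at the dose given), compound 1 gives 89.2%, compound 2 gives 85.6% and compound 3 gives 75.3%. Compound 3 holds the lowest of the three numbers: the step of a number 10.3 percentage points lower from compound 2 to compound 3 (beyond the scatter) and the step of a number 13.9 percentage points lower from compound 1 to compound 3 (beyond the scatter) both lie beyond the scatter, whereas the step of a number 3.6 percentage points lower from compound 1 to compound 2 (within the scatter) does not. Compound 4 `N#CC1=C(NC(=O)c2ccccc2O)N(c2ccccc2)C(=O)N2CCCCC(N3CCCC3)C12` is obtained from compound 3 by the change (a group of 10 heavy atoms (7 carbon, 1 nitrogen, 2 oxygen; one six-membered aromatic ring of carbon only) in place of a group of 10 heavy atoms (8 carbon, 1 nitrogen, 1 oxygen; one six-membered aromatic ring of carbon only), on a double-bonded ring carbon). The two steps that bear on this change are those leading into compound 3, since each replaced a group on the same ring carbon, and each lowered the number by a modest amount. The group entering in compound 4 carries an amino attachment, as do the groups of compound 1 and compound 2, while the group leaving compound 3 did not. Compound 4 is therefore expected to recover part of that loss, with an estimated step of a number 8.7 percentage points higher from compound 3 to compound 4 (within the scatter). In this assay compound 4 is estimated at 84%, within a range from 72% to 92%.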

Compound 4, a percentage reported as inhibition, in the whole organism at one dose (the size of the read-out at that dose, not a potency): 65.4%
For compound 4 the middle estimate is 18.6 percentage points above the measured one; the measured number lies below the stated range.
By their numbers in this assay, from the lowest: compounds 4 and 3 (each within the scatter of the next); then compounds 2 and 1 (each within the scatter of the next).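

In this assay, an amino attachment on the double-bonded ring carbon does not by itself keep a compound at the level of compound 1 and compound 2: the ((2-hydroxyphenyl)carbonyl)amino group carries such an attachment, yet the step is a number 20.2 percentage points lower from compound 2 to compound 4 (beyond the scatter). The same holds against the carboxymethyl group on the amine nitrogen, with the step of a number 23.8 percentage points lower from compound 1 to compound 4 (beyond the scatter), so what is attached to that nitrogen matters among these compounds, not only its presence. Against the group of compound 3, which has no such attachment, the step is a number 9.9 percentage points lower from compound 3 to compound 4 (within the scatter), so the four compounds fall into an upper pair, compound 1 and compound 2, and a lower pair, compound 3 and compound 4. No available information accounts for these differences.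

From the compounds shown here alone, whether the number of compound 1 belongs to the carboxymethyl group itself or would hold for a carboxyethyl chain on the same nitrogen stays open, as does any part of the ring hydroxyl of compound 4, which a plain benzoyl group would address. Going by these compounds, these are readings at a single dose, so how the compounds would rank in potency also remains open.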